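Rearranging the amide of compound 3 into an open amide

The source may hold more compounds than are shown below. What is called first, only, known or untested is meant among the compounds shown, and "the series" means these compounds.

Compound 1 `O=C([C@@H]1CCCN(S(=O)(=O)c2ccc(S(=O)(=O)C3CCC3)cc2)C1)N1CCC(F)(F)CC1` gives > 3000 nM in a functional assay on MIA PaCa-2 cells (Homo sapiens) for inhibition, read by MTT assay, with a stated time of 3 days; on this read-out lower numbers stand for stronger inhibition and higher numbers for weaker inhibition; this is a limit of the assay, not a number.
Compound 2 `O=C([C@@H]1CCCN(S(=O)(=O)c2ccc(S(=O)(=O)N3CC[C@@H](O)C3)cc2)C1)N1CCC(F)(F)CC1` gives > 3000 nM in this assay; this too is a limit.
Compound 3 `CCN(CC)S(=O)(=O)c1ccc(S(=O)(=O)N2CCC[C@@H](C(=O)N3CC[C@@H](OC)C3)C2)cc1` gives > 10000 nM in this assay; again only a limit.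

Compound 3 therefore stands at a limit, and none of the three compounds gives a real number. Two of the values sit at the limit of > 3000 nM in this assay, at which 2 of the 3 values shown sit, one at the limit of > 10000 nM in this assay, at which 1 of the 3 values shown sits. Within the data shown here, the only step between measured compounds, a step that the two limits leave unreadable from compound 1 to compound 2, cannot be read because both ends are limits.

Compound 4 `CCN(CC)S(=O)(=O)c1ccc(S(=O)(=O)N2CCC[C@@H](C(=O)NC3CCOCC3)C2)cc1` keeps every atom of compound 3 but joins them differently: (oxan-4-yl)amino in place of 3-methoxypyrrolidin-1-yl on a carbonyl carbon. The change sits on the carbonyl carbon next to the saturated ring carbon of the shared core. Among the measured compounds shown here, no measured step touches this part of the molecule, and the one step that exists is unreadable, so no direction can be taken from the data.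

With every measured value at a limit, compound 4 is expected to remain at a limit as well, around 15000 nM, with a range from 5000 nM to 50000 nM. The step that the limit leaves unreadable from compound 3 to compound 4 is thus estimated as no change beyond the scatter.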

Compound 4, half-maximal inhibitory concentration: > 10000 nM
Compound 4: only a limit was reported; the forecaster's own chance of this, stated with the estimate: 85%; the middle value does not contradict the limit.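

Compound 3 gives > 10000 nM in this assay, which is a limit and not a number. Among these compounds, compound 4 gives > 10000 nM, also a limit, so no step from compound 3 to compound 4 can be read. The compounds shown leave open which change to the shared core, if any, would give a real number here.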